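Aryl variation on the shared core: the step to compound 4

The source may hold more compounds than are shown below. What is called first, only, known or untested is meant among the compounds shown, and "the series" means these compounds.

Measured so far in a functional assay on NCI/ADR-RES cells (Homo sapiens) for inhibition, read by sulforhodamine B assay, with a stated time of 48 h; on this read-out higher numbers stand for weaker inhibition of growth and lower numbers for stronger inhibition of growth:
Compound 1 `CC1=CC[C@H](C(C)(C)NC(=S)N/N=C/c2ccccc2O)CC1` gives 3700 nM.
Compound 2 `CC1=CC[C@H](C(C)(C)NC(=S)N/N=C/c2ccc(N(C)C)cc2)CC1` gives > 100000 nM, which is a limit of the assay and not a number.
Compound 3 `CC1=CC[C@H](C(C)(C)NC(=S)N/N=C/c2ccc(F)cc2)CC1` gives > 100000 nM, likewise a limit of the assay and not a number.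

Compound 3 therefore stands at the limit of > 100000 nM in this assay, at which 2 of the 3 values shown sit; only compound 1 has a readable number in this assay. Among the measured compounds shown here, the one readable step into compound 3 is an at least 27-fold higher number from compound 1 to compound 3 (1.43 log units; beyond the scatter), a large step beyond the scatter. The step that the two limits leave unreadable from compound 2 to compound 3 cannot be sized, as both ends are limits.

The next change is 1H-pyrrol-2-yl in place of 4-fluorophenyl on a carbon with a double bond to nitrogen, giving compound 4 `CC1=CC[C@H](C(C)(C)NC(=S)N/N=C/c2ccc[nH]2)CC1`. For the measured compounds named here, no measured step covers this replacement; the only aryl group with a hydrogen-bond donor in the set, the 2-hydroxyphenyl of compound 1, is the only one with a number within range, but no step between compound 1 and compound 4 is available. Compound 4 is therefore estimated at 30000 nM, with a range from 4000 nM to 120000 nM. The expected step is an at least 3.3-fold lower number from compound 3 to compound 4 (0.52 log units; beyond the scatter), with a substantial chance that only a limit is reported again.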

Compound 4, concentration for 50% growth inhibition: 78000 nM
Compound 4: middle estimate off by 2.6-fold (0.41 log units), on the low side, and the stated range covers the measured number.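

The 1H-pyrrol-2-yl group carries a hydrogen-bond donor, yet replacing 2-hydroxyphenyl with it gives a 21-fold higher number from compound 1 to compound 4 (1.32 log units; beyond the scatter), so a donor on this group does not alone keep growth inhibition at the level of compound 1. Replacing 4-fluorophenyl gives an at least 1.2-fold lower number from compound 3 to compound 4 (0.10 log units; that floor lies within the scatter), only a floor, so the 1H-pyrrol-2-yl group cannot be placed firmly ahead of 4-fluorophenyl. Compound 4 adds a second readable number at this position in this assay, where the other values sit at a limit of the assay: the limit of > 100000 nM in this assay, at which 2 of the 4 values shown sit.

The compounds shown leave open whether the readable value of compound 1 depends on its hydroxyl, a question that an unsubstituted phenyl or a 2-methoxyphenyl group at this place would address. Also open, as far as these compounds go, is whether a pyridin-2-yl group would behave like the 1H-pyrrol-2-yl group.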